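A few compounds are considered here, and "the series" means these few. Any claim that something is new, unique, unknown or untested is made for them only; others in the source may bear on it.

Working notes on the series. Two compounds have been run in a functional assay on HeLa cells (Homo sapiens) for antiproliferative activity, read by MTT assay, with a stated time of 72 h (on this read-out higher numbers stand for weaker inhibition and lower numbers for stronger inhibition), so far: compound 1 `O=c1[nH]c(=O)n(CCC(CO)CO)cc1-c1cccs1` and compound 2 `CCCCCCCCC#Cc1cn(CCC(COC(C)=O)COC(C)=O)c(=O)n(C(=O)c2ccccc2)c1=O`. In this assay compound 1 gives 7800 nM, the lowest of the two numbers in hand. In this assay, among the measured compounds shown here, compound 2 gives 32400 nM, a value beyond the scatter from that of compound 1; no single-place step joins these two compounds, so the two values are only set side by side. Compound 3 `O=c1[nH]c(=O)n(CCC(CO)CO)cc1C#CCCCCl` is not yet measured in this assay. It departs from compound 1 in one place: 5-chloropent-1-yn-1-yl in place of thiophen-2-yl on an aromatic carbon. For the measured compounds named here, no measured pair shows this exchange, so the size of the step rests on expectation alone. The expected step from compound 1 to compound 3 in this assay is a 1.5-fold higher number from compound 1 to compound 3 (0.19 log units; within the scatter), a small move toward weaker inhibition that may not exceed the scatter, with wide uncertainty in either direction. Compound 3 is therefore estimated at 12000 nM in this assay, within a range from 4000 nM to 40000 nM.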

Compound 3, half-maximal inhibitory concentration: > 100000 nM
Compound 3: only a limit was reported; the forecaster's own chance of this, stated with the estimate: 15%; middle value at least 8.3-fold (0.92 log units) from the limit.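

In this assay, among the compounds shown here, exchanging thiophen-2-yl for 5-chloropent-1-yn-1-yl on this aromatic carbon gives an at least 12-fold higher number from compound 1 to compound 3 (1.10 log units; beyond the scatter), the first single-place step, and it shows that the read-out depends on what this position carries. The exchange replaces a five-membered aromatic ring with a chain that has no ring but has a triple bond and a chlorine. The value of compound 3 is a limit of the assay and not a number, so the step fixes only a minimum size for the change: the limit of > 100000 nM in this assay, at which 1 of the 3 values shown sits.

As far as these compounds go, it remains open whether the ring, the triple bond or the chlorine accounts for the step. Furan-2-yl or phenyl at this carbon, or a pent-1-yn-1-yl chain without the chlorine or ending in an amine, would separate these parts.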